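Swapping the Ethynyl Group for a Furan Ring

The source may hold more compounds than are shown below. What is called first, only, known or untested is meant among the compounds shown, and "the series" means these compounds.

Measured so far:
Compound 1, `C#Cc1cn([C@@H]2O[C@H](CO)[C@@H](O)[C@H]2O)c2ncnc(N(C)C)c12`: 810 nM
Compound 2, `C#Cc1cn([C@@H]2O[C@H](CO)[C@@H](O)[C@H]2O)c2ncnc(OC)c12`: 1730 nM

Both compounds were tested in a functional assay on HeLa S3 cells (Homo sapiens) for antiproliferative activity, read by XTT assay, with a stated time of 72 h; on this read-out higher numbers stand for weaker inhibition and lower numbers for stronger inhibition. On the numbers shown, compound 2 has the highest value of the two; its nearest neighbour is compound 1, and the step of a 2.1-fold higher number from compound 1 to compound 2 (0.33 log units; beyond the scatter) separates them. That step comes from a single change, a methoxy in place of a dimethylamino on an aromatic carbon, and it leaves the ethynyl group untouched.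

Compound 3, `COc1ncnc2c1c(-c1ccco1)cn2[C@@H]1O[C@H](CO)[C@@H](O)[C@H]1O`, is not yet measured. It differs from compound 2 in one place: furan-2-yl in place of ethynyl on an aromatic carbon. Among the measured compounds shown here, no measured step touches this position, so the one step recorded says nothing direct about how the furan-2-yl group will behave in this assay. With nothing to anchor a direction, the expectation for compound 3 is a value near that of compound 2, with the step of a 1.2-fold higher number from compound 2 to compound 3 (0.06 log units; within the scatter) expected to stay within the scatter, though the uncertainty is wide. Compound 3 is therefore estimated at 2000 nM, with a range from 500 nM to 8000 nM.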

Compound 3, half-maximal inhibitory concentration: 1020 nM
For compound 3 the middle estimate is 2.0-fold (0.29 log units) above the measured one, and the stated range covers the measured number.
By their numbers in this assay, from the lowest: compounds 1, 3 and 2 (each within the scatter of the next, the first and the last beyond it).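

Among the compounds shown here, the earlier compounds changed only the group on the other side of the shared core, so this is the first measured change at the aromatic carbon of the five-membered aromatic ring, two ring bonds from the ring nitrogen. In this assay, replacing ethynyl with furan-2-yl gives a 1.7-fold lower number from compound 2 to compound 3 (0.23 log units; within the scatter), so this read-out does not separate the two groups. The position therefore accepts a group with 5 heavy atoms, a ring of its own and a hydrogen-bond acceptor in place of one with 2 heavy atoms and no ring, and nothing available explains this result.

Going by these compounds, two groups at one position do not define a trend, so it remains open how this carbon would respond to a phenyl ring, an aminomethyl group, a carboxylic acid or a longer chain such as hexynyl. On these data alone, it is also open whether furan-2-yl would give a similar reading when paired with the dimethylamino group of compound 1 rather than the methoxy group of compound 3.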